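Quinoxaline-diamine series: third methoxy on the benzyl amine

A few compounds are considered here, and "the series" means these few. Any claim that something is new, unique, unknown or untested is made for them only; others in the source may bear on it.

Measured so far:
compound 1, `Nc1cc(N)c2nc(-c3ccccc3)c(NCc3ccc(Cl)c(Cl)c3)nc2c1` — 34700 nM
compound 2, `COc1ccc(CNc2nc3cc(N)cc(N)c3nc2-c2ccccc2)cc1OC` — 77600 nM

Both were read in a functional assay on SK-MEL-5 cells (Homo sapiens) for inhibition, read by sulforhodamine B assay, with a stated time of 48 h; on this read-out lower numbers stand for higher toxicity in this test and higher numbers for lower toxicity in this test. Within the data shown here, compound 2 gives the higher of the two numbers; the only neighbour with a number is compound 1, and the step of a 2.2-fold higher number from compound 1 to compound 2 (0.35 log units; beyond the scatter) is the one measured comparison in the set.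

Compound 3, `COc1cc(CNc2nc3cc(N)cc(N)c3nc2-c2ccccc2)cc(OC)c1OC`, has not been measured. Its change from compound 2 is methoxy in place of hydrogen on an aromatic carbon.

Among the measured compounds shown here, no measured step tests a third methoxy on this ring; the only step that touches the same ring, a 2.2-fold higher number from compound 1 to compound 2 (0.35 log units; beyond the scatter), swapped two chlorines for two methoxy groups and moved the number up modestly. That bears on compound 3 only loosely. The expected step of a 1.2-fold higher number from compound 2 to compound 3 (0.09 log units; within the scatter) is therefore small, in the direction of a somewhat higher number, and may stay within the scatter. In this assay compound 3 is expected at about 95000 nM, with a range of 40000 nM to 220000 nM.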

Compound 3, concentration lethal to 50% of the cells: 29500 nM
Compound 3: the middle estimate sits 3.2-fold (0.51 log units) above what was measured; the measured number lies below the stated range.
By their numbers in this assay, from the lowest: compounds 3 and 1 (each within the scatter of the next); then compound 2.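

In this assay, methoxy in place of hydrogen on an aromatic carbon, ortho to a methoxy group, gives a 2.6-fold lower number from compound 2 to compound 3 (0.42 log units; beyond the scatter), so the number at this position does respond to substitution. The direction is opposite to that of a 2.2-fold higher number from compound 1 to compound 2 (0.35 log units; beyond the scatter), which means that more methoxy groups on this ring do not simply go with a higher number across compounds 1, 2 and 3. No measured property in hand bears on the reason for this fall.

Only methoxy and hydrogen are shown at this carbon, so a hydroxyl, a fluorine atom or an ethoxy group there would be needed to tell whether the fall is specific to methoxy. Going by these compounds, whether the same addition acts alike on the 3,4-dichlorophenyl ring of compound 1 also stays open.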